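This account rests on a few compounds, and the source may have more. Where it says the series, first, only, none or still open, it means among the compounds named here.

Measured so far in a functional assay on MOLT-4 cells (Homo sapiens) for inhibition, read by sulforhodamine B assay, with a stated time of 48 h, tested at 10 uM; on this read-out lower numbers stand for less inhibition of growth and higher numbers for more inhibition of growth at the one concentration tested:
- compound 1 `CCOC(=O)c1ccc(Nc2ccnc(SCC(=O)c3ccc(C#N)cc3)n2)cc1`: 84%
- compound 2 `CC(=O)c1cccc(Nc2ccnc(SCC(=O)c3ccc(-c4ccccc4)cc3)n2)c1`: 29%

Compound 2 stands at the lower of the two numbers. Compound 1 gives the higher one, and the gap between them lies beyond the usual scatter. Within the data shown here, the two differ in more than one place, so no single step between them is computed, and they say nothing about any one change on its own.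

Compound 3 `COc1ccc(C(=O)CSc2nccc(Nc3cccc(C(C)=O)c3)n2)cc1` is the next compound, not yet measured. It differs from compound 2 in one place: methoxy in place of phenyl on an aromatic carbon. Among the measured compounds shown here, no measured pair shows this exchange, so nothing known here gives the size or direction of its step; a step of modest size in either direction, or none beyond the scatter, would all fit. In this assay compound 3 is expected near 33%, within 5% to 65%. The step of a number 4 percentage points higher from compound 2 to compound 3 (within the scatter) is expected to be small.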

Compound 3, percent growth inhibition at one concentration: 53%
Beside the measured number, compound 3's estimate is 20 percentage points below it; the range from low to high includes it.
By their numbers in this assay, from the lowest: compound 2; then compound 3; then compound 1.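

At the aromatic carbon para to a large group, the position is not indifferent to its substituent in this assay: methoxy in place of phenyl gives more growth inhibition (a number 24 percentage points higher from compound 2 to compound 3 (beyond the scatter)). Among these compounds, this is the first step that can be read at a single place, and it shows that the phenyl is not needed at this position for inhibition of growth at the one concentration tested. No available evidence bears on why this exchange raises the number.

One step cannot separate the loss of the phenyl from the arrival of the methoxy. An ethoxy group, a chlorine atom or a dimethylamino group at the same carbon would show whether the number follows the size of the group or the presence of its oxygen.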